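This account rests on a few compounds, and the source may have more. Where it says the series, first, only, none or still open, it means among the compounds named here.

In a functional assay on cells (Panel ovarian (Carcinoma cell lines), Homo sapiens) for inhibition (on this read-out lower numbers stand for stronger inhibition of growth and higher numbers for weaker inhibition of growth), compound 1 (`Cc1cc(C)c2c(O)cc(-c3cccc(F)c3)nc2n1`) gives 5500 nM and compound 2 (`Cc1cnc2[nH]c(-c3cccc(Cl)c3)cc(=O)c2c1`) gives 15800 nM. Compound 2 therefore has the higher of the two numbers, which means weaker growth inhibition, and the gap lies beyond the usual scatter. These two compounds differ in more than one place, so their gap cannot be tied to any single change.

The unmeasured compound 3 (`Cc1cnc2[nH]c(-c3cccc(F)c3)cc(=O)c2c1`) differs from compound 2 in one place: fluoro in place of chloro on an aromatic carbon. In words, this is fluoro in place of chloro on an aromatic carbon. Going by the values given here, no measured pair shows this exchange, so the guidance is thin. Compound 1 also carries fluoro, on a different core, and its 5500 nM hints only weakly at a lower number. The estimate is a 1.3-fold lower number from compound 2 to compound 3 (0.12 log units; within the scatter), an expected step that stays within the scatter. For compound 3 the expected value is 12000 nM, with an estimated range from 5000 nM to 30000 nM.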

Compound 3, concentration for total growth inhibition: 26900 nM
The estimate for compound 3 lay 2.2-fold (0.35 log units) below the measured number; the range from low to high includes it.
By their numbers in this assay, from the lowest: compound 1; then compounds 2 and 3 (each within the scatter of the next).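

In this assay, the exchange of chloro for fluoro on this aromatic carbon, meta to a large group, can now be read directly as a single change (a 1.7-fold higher number from compound 2 to compound 3 (0.23 log units; within the scatter)). At this position on the shared core, the two groups cannot be told apart, as the exchange leaves growth inhibition within the ordinary noise of the test. Nothing measured on these compounds offers an explanation of this result.

As far as these compounds go, whether a different kind of group at this position, such as an amine or a carboxylic acid, would move the number beyond the scatter remains open. It is also unresolved which feature separates compound 1 from compound 2, as they differ in more than one place.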